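Hydroxy to acetoxy on compound 3

The source may report more compounds than this note shows. Statements on the series, on what has been measured and on what is new or still open speak of the compounds shown alone.

Measured in a functional assay on T47D cells (Homo sapiens) for cytotoxicity, read by colorimetric assay and MTT assay; on this read-out lower numbers stand for stronger inhibition and higher numbers for weaker inhibition:
Compound 1 `COC(=O)CCn1c(=O)c(-c2ccc(OC)cc2)cc2c(OC)cc(OC)cc21`: 10000 nM
Compound 2 `COc1cc(OC)c2cc(-c3ccc(O)cc3)c(O)nc2c1`: 10000 nM
Compound 3 `COc1cc(OC)c2cc(-c3ccc(O)cc3)c(=O)n(C)c2c1`: 10000 nM

Compound 3 stands level with compound 1 and compound 2, with nothing separating the three at the digits reported. For the measured compounds named here, no measured pair differs in one place only, so no measured step is available as a guide. Compound 4 `COc1cc(OC)c2cc(-c3ccc(OC(C)=O)cc3)c(=O)n(C)c2c1` differs from compound 3 by acetyl in place of hydrogen on an oxygen on an aromatic ring, a change of hydroxy to acetoxy. In this assay, the expectation is no shift beyond the scatter, with any small move more likely toward stronger inhibition. The estimated outcome is a 1.3-fold lower number from compound 3 to compound 4 (0.10 log units; within the scatter). Compound 4 is estimated at 8000 nM, with an expected range of 3000 nM to 13000 nM.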

Compound 4, half-maximal inhibitory concentration: 10000 nM
The estimate for compound 4 lay 1.3-fold (0.10 log units) below the measured number; the range from low to high includes it.
By their numbers in this assay, from the lowest: compounds 1, 2, 3 and 4 (each within the scatter of the next).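

In this assay, for the compounds shown here, acetyl in place of hydrogen on an oxygen on an aromatic ring gives no change at the digits printed from compound 3 to compound 4 (within the scatter), the first comparison that differs in one place. At this position, the hydroxy and acetoxy forms cannot be told apart on this read-out. No supporting data bear on the reason for this result.

Open, on these data alone, is whether a longer acyl chain in place of acetyl, or an amine or carboxylic acid carried on this oxygen, would give a number apart from compound 3. Changes elsewhere on the shared core also remain untested by any single-place comparison shown.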